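One aryl swap carried across two related cores

The compounds below may be only part of what the source reports. "The series", "measured", "known", "first", "only" and "open" are said of these compounds alone.

Compound 1 `CC(C)=CCC/C(C)=C/CC/C(C)=C/CC[C@@H]1[C@@]2(C)CC/C(=N\OCc3cn(-c4cccc(O)c4)nn3)C(C)(C)[C@@H]2CC[C@@]1(C)O` and compound 2 `CC(C)=CCC/C(C)=C/CC/C(C)=C/CC[C@@H]1[C@@]2(C)CC/C(=N\OCc3cn(-c4ccc(F)c(Cl)c4)nn3)C(C)(C)[C@@H]2CC[C@@]1(C)O` share one core, while compound 3 `CC(C)=CCC/C(C)=C/CC/C(C)=C/CC[C@@H]1[C@@]2(C)C/C(=C\c3ccc(OCc4cn(-c5cccc(O)c5)nn4)cc3)C(=O)C(C)(C)[C@@H]2CC[C@@]1(C)O` and compound 4 `CC(C)=CCC/C(C)=C/CC/C(C)=C/CC[C@@H]1[C@@]2(C)C/C(=C\c3ccc(OCc4cn(-c5ccc(F)c(Cl)c5)nn4)cc3)C(=O)C(C)(C)[C@@H]2CC[C@@]1(C)O` share another; the difference between the two cores is not broken down here. In a functional assay on MCF7 cells (Homo sapiens) for cytotoxicity, read by MTT assay, with a stated time of 48 h (on this read-out higher numbers stand for weaker inhibition and lower numbers for stronger inhibition), compound 1 gives 9900 nM. Compound 2 gives 31400 nM. Compound 3 gives 45500 nM. Going from compound 1 to compound 2 the change is 3-chloro-4-fluorophenyl in place of 3-hydroxyphenyl on an aromatic nitrogen, and it made a 3.2-fold higher number from compound 1 to compound 2 (0.50 log units; beyond the scatter). The same change, (3-chloro-4-fluorophenyl in place of 3-hydroxyphenyl on an aromatic nitrogen), turns compound 3 into compound 4. Compound 4 is expected to show a 2.4-fold higher number from compound 3 to compound 4 (0.38 log units; beyond the scatter), because a 3.2-fold higher number from compound 1 to compound 2 (0.50 log units; beyond the scatter) was seen on the other core and nothing in the three measured compounds argues against a similar step here. For compound 4 the estimated value in this assay is 110000 nM, expected to fall between 45000 nM and 250000 nM, with a real chance that the assay reports only a limit.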

Compound 4, half-maximal inhibitory concentration: 46500 nM
Compound 4: the middle estimate sits 2.4-fold (0.37 log units) above what was measured; low and high end bracket the measured number.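

In this assay, putting 3-chloro-4-fluorophenyl in place of 3-hydroxyphenyl on the core of compound 3 gives a 1.0-fold higher number from compound 3 to compound 4 (0.01 log units; within the scatter), so this step stays within the usual scatter. The same change therefore did not carry over from one core to the other, and its size on the first core was a poor guide to its size on the second: the same change on two cores in this assay, a 3.2-fold higher number (0.50 log units; beyond the scatter) from compound 1 to compound 2 and a 1.0-fold higher number (0.01 log units; within the scatter) from compound 3 to compound 4, 3.1-fold (0.49 log units) apart, beyond the scatter of two such steps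

With a single pair on each core, this does not show why the two steps differ, nor whether other changes at this place would also depend on the core. Still open, from the compounds shown here alone, is how a phenyl ring carrying an amine or a carboxylic acid would behave on the aromatic nitrogen of each core. A plain phenyl ring on that nitrogen would raise the same question.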